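Taking Away the Imidazolylethoxy Group from Compound 3

A few compounds are considered here, and "the series" means these few. Any claim that something is new, unique, unknown or untested is made for them only; others in the source may bear on it.

Three measured compounds share one core, differing only in a group on the outer aromatic ring. Compound 1 `CN(C)c1cccc(Nc2nccc(-c3cccs3)n2)c1` gives 2400 nM in a functional assay for inhibition, with Homo sapiens as the target; a higher number here means a weaker inhibitor, a lower number a stronger inhibitor. Compound 2 `CC1CCN(c2ccc(Nc3nccc(-c4cccs4)n3)cc2)CC1` gives 400 nM. Compound 3 `c1cc(Nc2nccc(-c3cccs3)n2)cc(OCCn2ccnc2)c1` gives 100 nM, the lowest of the three numbers; the nearest is compound 2, the furthest compound 1. One step connects two of them: a 24-fold lower number from compound 1 to compound 3 (1.38 log units; beyond the scatter).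

Compound 4 `c1ccc(Nc2nccc(-c3cccs3)n2)cc1` is not yet measured. It differs from compound 3 in one place: hydrogen in place of 2-(1H-imidazol-1-yl)ethoxy on an aromatic carbon. Going by the values given here, only the step from compound 1 to compound 3 touches this group, and there the 2-(1H-imidazol-1-yl)ethoxy group arrived as a swap for dimethylamino, not from hydrogen, so the size of that step sets only a loose guide. Since the group in compound 3 went with the lowest number, taking it away is expected to raise the number: a 10-fold higher number from compound 3 to compound 4 (1.00 log units; beyond the scatter). Compound 4 is therefore expected to give about 1000 nM, within a range of 300 nM to 4000 nM.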

Compound 4, half-maximal inhibitory concentration: 31700 nM
Compound 4: middle estimate off by 32-fold (1.50 log units), on the low side, outside the stated range (above it).
By their numbers in this assay, from the lowest: compound 3; then compound 2; then compound 1; then compound 4.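

Going by these compounds alone, with a 320-fold higher number from compound 3 to compound 4 (2.50 log units; beyond the scatter) in this assay, the outer ring without any group now supplies a baseline that the earlier compounds, each carrying a group there, could not give. Against that baseline, the 2-(1H-imidazol-1-yl)ethoxy group is not the only group that matters: a 79-fold higher number from compound 2 to compound 4 (1.90 log units; beyond the scatter) on losing 4-methylpiperidin-1-yl and a 13-fold higher number from compound 1 to compound 4 (1.12 log units; beyond the scatter) on losing dimethylamino show that all three groups go with a lower number than hydrogen, and no compound here goes against this. No measurement at hand gives a cause for the size of these steps.

On these data alone, whether the gain needs the imidazole ring remains open, and a plain methoxy group or an ethoxy chain ending in a morpholine would help separate the ring from the chain. As far as these compounds go, how much the place on the outer ring counts also remains open, as the 2-(1H-imidazol-1-yl)ethoxy group appears at only one carbon.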